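The source may hold more compounds than are shown below. What is called first, only, known or untested is meant among the compounds shown, and "the series" means these compounds.

In an assay on isolated protein for agonist activity at Bile acid receptor (Homo sapiens), read by FRET (on this read-out higher numbers stand for larger maximal responses and lower numbers for smaller maximal responses), compound 1 `CC(C)c1onc(-c2c(Cl)cccc2Cl)c1COc1ccc(N(C)C(=O)c2ccc(C(=O)O)cc2)c(C(F)(F)F)n1` gives 101%. Compound 3 `Cc1cc(OCc2c(-c3c(Cl)cccc3Cl)noc2C(C)C)ncc1[N+](=O)[O-]` gives 101% in this assay, and compound 2 `Cc1nc(OCc2c(-c3c(Cl)cccc3Cl)noc2C(C)C)ccc1N(C)C(=O)c1ccc(C(=O)O)cc1` gives 95%. Compound 1 is level with compound 3 at the digits shown, the two together being the highest of the three numbers, and the only measured step is a number 6 percentage points lower from compound 1 to compound 2 (within the scatter), a change at a different part of the core. Compound 4 `CC(C)c1onc(-c2c(Cl)cccc2Cl)c1COc1ccc(N(C)Cc2ccc(OCC(=O)O)cc2)c(C(F)(F)F)n1` differs from compound 1 by 4-(carboxymethoxy)benzyl in place of (4-carboxyphenyl)carbonyl on a nitrogen on an aromatic ring. Among the measured compounds shown here, no measured step bears on this exchange, so it is not anchored by the numbers at hand. Compound 4 is expected to give 85%, between 50% and 110%, with the estimated step being a number 16 percentage points lower from compound 1 to compound 4 (beyond the scatter).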

Compound 4, largest response reached (reported as efficacy), in percent of the reference or control that the assay uses: 90%
Compound 4: middle estimate off by 5 percentage points, on the low side; the measured number falls inside the stated range.
By their numbers in this assay, from the lowest: compounds 4, 2, 1 and 3 (each within the scatter of the next, the first and the last beyond it).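

Among the compounds shown here, the exchange of (4-carboxyphenyl)carbonyl for 4-(carboxymethoxy)benzyl on the nitrogen gives a number 11 percentage points lower from compound 1 to compound 4 (beyond the scatter) in this assay, the first measured change at this position. Even without the carbonyl on that nitrogen, compound 4 still gives 90% as a maximal response. Nothing at hand explains the drop.

The exchange alters the link on the nitrogen and the chain carrying the carboxylic acid together, and the two effects cannot be separated here. As far as these compounds go, whether an amine could stand in place of the carboxylic acid remains open.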